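The source may report more compounds than this note shows. Statements on the series, on what has been measured and on what is new or still open speak of the compounds shown alone.

Compound 1 `Cc1nc(C(=O)Nc2ccc(Cl)c(-c3nnc4c(Cl)cccn34)c2)cs1` stands at the edge of what a functional assay on MDA-MB-468 cells (Homo sapiens) for antiproliferative activity, read by MTT assay, with a stated time of 72 h (on this read-out lower numbers stand for stronger inhibition and higher numbers for weaker inhibition), can read: in this assay compound 1 gives > 100000 nM, which is a limit of the assay and not a number. Compound 2 `O=C(Nc1ccc(Cl)c(-c2nnc3c(Cl)cccn23)c1)c1cccc(Cl)c1` gives 54800 nM. Compound 3 `O=C(Nc1ccc(Cl)c(-c2nnc3c(Cl)cccn23)c1)c1ccon1` gives > 100000 nM, again a limit. Compound 4 `O=C(Nc1ccc(Cl)c(-c2nnc3c(Cl)cccn23)c1)c1cccnc1Cl` differs from compound 1 in one place: 2-chloropyridin-3-yl in place of 2-methyl-1,3-thiazol-4-yl on a carbonyl carbon. Going by the values given here, two measured steps bear on it. The step of an at least 1.8-fold lower number from compound 1 to compound 2 (0.26 log units; that floor lies within the scatter) shows that a 3-chlorophenyl on the carbonyl carbon brings a readable number, while the step that the two limits leave unreadable from compound 1 to compound 3 shows a 1,2-oxazol-3-yl staying at the limit (the limit of > 100000 nM in this assay, at which 2 of the 3 values shown sit). The 2-chloropyridin-3-yl of compound 4 is closer to the first case, so compound 4 is expected to reach an estimated 60000 nM, within a range of 20000 nM to 150000 nM. The expected step is then an at least 1.6-fold lower number from compound 1 to compound 4 (0.22 log units; that floor lies within the scatter).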

Compound 4, half-maximal inhibitory concentration: > 100000 nM
Compound 4 ended at the assay's limit (the forecaster's own chance of this, stated with the estimate: 40%); middle value at least 1.6-fold (0.22 log units) away from the limit.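

In this assay compound 4 gives > 100000 nM, which is a limit of the assay and not a number. A chlorine-bearing six-membered aromatic ring on the carbonyl carbon therefore does not by itself bring a readable number, though the step of an at least 1.8-fold higher number from compound 2 to compound 4 (0.26 log units; that floor lies within the scatter) cannot show how far apart the two compounds really lie. The steps from compound 1 and compound 3 to compound 4 cannot be read, and compound 4 joins the compounds at the limit: the limit of > 100000 nM in this assay, at which 3 of the 4 values shown sit.

Still open, as far as these compounds go, is whether a cyclohexyl ring or a longer carbon chain on the carbonyl carbon, in place of these aromatic rings, would give a readable number in this assay.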